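This account rests on a few compounds, and the source may have more. Where it says the series, first, only, none or still open, it means among the compounds named here.

Notes on the series. Compound 1 `COc1ccc2nccc(C3CN(CCCNCc4cc5ccccc5[nH]4)C(=O)O3)c2c1` gives 1580 nM in an in vitro functional assay on RBL cells for antagonist activity at C-C chemokine receptor type 8 (Homo sapiens), read by FLIPR and calcium flux; on this read-out higher numbers stand for weaker inhibition and lower numbers for stronger inhibition. Compound 2 `O=C1OC(c2cnc3ccccc3c2)CN1C1CCN(Cc2cc3ccccc3[nH]2)CC1` reaches only a limit of the assay, < 50200 nM, with no number behind it (the limit of < 50200 nM in this assay, at which 1 of the 3 values shown sits). Compound 3 `COc1ccc2nccc(C3CN(C4CCN(Cc5cc6ccccc6s5)CC4)C(=O)O3)c2c1` gives 794 nM and holds the lowest of the two numbers, though compound 1 sits within the scatter of it, so no order between the two is claimed. Compound 4 `COc1ccc2nccc(C3CN(C4CCN(S(=O)(=O)c5ccc(Cl)c(Cl)c5)CC4)C(=O)O3)c2c1` is not yet measured; it differs from compound 3 only as (3,4-dichlorophenyl)sulfonyl in place of (1-benzothiophen-2-yl)methyl on an amine nitrogen in a ring. Among the measured compounds shown here, no step between measured compounds covers this change, so compound 4 is expected to move by a modest amount toward weaker inhibition, a step of a 3.1-fold higher number from compound 3 to compound 4 (0.50 log units; beyond the scatter) in this assay. Compound 4 is estimated at 2500 nM, within 500 nM to 12000 nM.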

Compound 4, half-maximal inhibitory concentration: < 50200 nM
Compound 4 was reported as a limit (the forecaster's own chance of this, stated with the estimate: 10%); the middle value is on the limit's open side.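

In this assay, among the compounds shown here, compound 4 gives only a limit, < 50200 nM, so no step from compound 3 to compound 4 can be read. On these data alone, whether (3,4-dichlorophenyl)sulfonyl in place of (1-benzothiophen-2-yl)methyl shifts inhibition, and by how much, stays open.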